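Carbamate oxygen substituents on a shared core

The source may hold more compounds than are shown below. What is called first, only, known or untested is meant among the compounds shown, and "the series" means these compounds.

Compound 1, `C[C@H](CF)OC(=O)N1CCC(O[C@H]2CC[C@H](Oc3cnc(S(C)(=O)=O)cn3)CC2)CC1`, in a functional assay on isolated protein for agonist activity at Glucose-dependent insulinotropic receptor (Homo sapiens), read by HTRF and cAMP accumulation; a higher number here means that more compound is needed for the effect, a lower number that less compound is needed: 36.8 nM. Compound 2, `CS(=O)(=O)c1cnc(O[C@H]2CC[C@H](OC3CCN(C(=O)OC4CCOC4)CC3)CC2)cn1`, in this assay: 427 nM.

Among the measured compounds shown here, compound 2 gives the highest of the two numbers measured so far; its only neighbour is compound 1, and the step of a 12-fold higher number from compound 1 to compound 2 (1.06 log units; beyond the scatter) arose from a single exchange at the oxygen next to the carbonyl group. Compound 3, `CS(=O)(=O)c1cnc(O[C@H]2CC[C@H](OC3CCN(C(=O)Oc4ccccc4)CC3)CC2)cn1`, is not yet measured. It differs from compound 2 by phenyl in place of oxolan-3-yl on an oxygen next to a carbonyl group. For the measured compounds named here, the one measured step bears on the same position and was large, showing that this oxygen substituent moves the number strongly, but it does not tell the direction for a phenyl group. For compound 3 the author therefore expects a value near the middle of the measured span, estimated as 200 nM with a range from 50 nM to 800 nM. This corresponds to an expected step of a 2.1-fold lower number from compound 2 to compound 3 (0.33 log units; beyond the scatter).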

Compound 3, half-maximal effective concentration: 9.6 nM
Estimate against measurement, compound 3: 21-fold (1.32 log units) above; the whole stated range lies above it.
By their numbers in this assay, from the lowest: compound 3; then compound 1; then compound 2.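

With phenyl on an oxygen next to a carbonyl group, the number in this assay moves the opposite way to the earlier exchange at this oxygen, and the step is large (a 44-fold lower number from compound 2 to compound 3 (1.65 log units; beyond the scatter)). Phenyl also goes past the 1-(fluoromethyl)ethyl group (a 3.8-fold lower number from compound 1 to compound 3 (0.58 log units; beyond the scatter)), so among these three compounds the lowest number belongs to the only group with an aromatic ring, though a single example cannot show that the ring itself is what matters. Nothing measured here explains why this oxygen substituent moves the number so strongly.

From the compounds shown here alone, whether a fluorine or a methoxy group on the phenyl ring would lower the number further remains open. So does whether a benzyl group or a pyridyl ring at this oxygen would keep the gain seen with phenyl.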